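The source may hold more compounds than are shown below. What is called first, only, known or untested is meant among the compounds shown, and "the series" means these compounds.

Compound 1 `Clc1ccc(-c2cc(-c3cccnc3)nc(-c3ccsc3)c2)o1`: 21600 nM
Compound 2 `Cc1ccc(-c2cc(-c3ccc(Cl)o3)cc(-c3ccsc3)n2)o1`: 18500 nM
Compound 3 `Clc1ccc(-c2cc(-c3ccc(Cl)o3)cc(-c3ccsc3)n2)cc1`: 19500 nM

All three were tested in a functional assay on DU-145 cells (Homo sapiens) for cytotoxicity, in the presence of a further agent that is not named here; on this read-out higher numbers stand for weaker inhibition and lower numbers for stronger inhibition. Compound 3 gives 19500 nM, and this sits in one narrow band with compound 1 and compound 2: the gap a 1.1-fold higher number from compound 2 to compound 3 (0.02 log units; within the scatter) and the gap a 1.1-fold lower number from compound 1 to compound 3 (0.04 log units; within the scatter) both lie within the scatter, so none of the three can be told apart from the others on this read-out.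

Compound 4 `Clc1ccc(-c2cc(-c3ccsc3)nc(-c3ccccc3Cl)c2)o1` has not yet been measured. It differs from compound 3 in one place: 2-chlorophenyl in place of 4-chlorophenyl on an aromatic carbon. For the measured compounds named here, three measured steps bear on this position, because each of them exchanged the group on that same aromatic carbon: a 1.2-fold lower number from compound 1 to compound 2 (0.07 log units; within the scatter), a 1.1-fold lower number from compound 1 to compound 3 (0.04 log units; within the scatter) and a 1.1-fold higher number from compound 2 to compound 3 (0.02 log units; within the scatter). Every one of them stayed within the scatter, although none exchanged one chlorophenyl for another, so the nearest guide is that changing the group at this position has so far left this assay unmoved. No step beyond the scatter is therefore expected for compound 4 in this assay. Compound 4 is estimated at 19500 nM, with a range from 9000 nM to 42000 nM. This estimate means a step of no change at the digits printed from compound 3 to compound 4 (within the scatter), expected to remain within the scatter.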

Compound 4, half-maximal inhibitory concentration: 19300 nM
The estimate for compound 4 lay 1.0-fold (0.00 log units) above the measured number; measured number inside the range.
By their numbers in this assay, from the lowest: compounds 2, 4, 3 and 1 (each within the scatter of the next).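

For the compounds shown here, this is the first exchange at this position that keeps the same atoms and changes only how they are joined, and in this assay the swap of 4-chlorophenyl for 2-chlorophenyl gives a 1.0-fold lower number from compound 3 to compound 4 (0.00 log units; within the scatter) with no measurable consequence. The new group also cannot be told apart from the other two groups tried on this aromatic carbon next to the ring nitrogen: the comparison with 5-methylfuran-2-yl gives a 1.0-fold higher number from compound 2 to compound 4 (0.02 log units; within the scatter) and the comparison with pyridin-3-yl gives a 1.1-fold lower number from compound 1 to compound 4 (0.05 log units; within the scatter) on the same read-out. All four compounds therefore sit in one band, so neither the kind of ring at this position nor the placement of its chlorine has yet moved the number beyond the scatter.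

Still open, as far as these compounds go, is whether a quite different group on this carbon, such as an amine, a carboxylic acid or a longer alkyl chain, would shift the result beyond the scatter. Nothing measured here offers an explanation for why this position has stayed so flat.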